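This account rests on a few compounds, and the source may have more. Where it says the series, first, only, none or still open, it means among the compounds named here.

Going by the values given here, in an ADME assay on BJ cells (Homo sapiens) for cytotoxicity, with a stated time of 72 h (on this read-out lower numbers stand for an effect already at smaller amounts and higher numbers for an effect only at larger amounts of compound), compound 3 `Cc1ccccc1-c1nc2c(c(C)nn2-c2ccccc2)c(-c2ccccc2O)c1C#N` gives 21000 nM, the only true number so far. Compound 1 `CCc1ccc(-c2nc3c(c(C)nn3-c3ccccc3)c(-c3ccccc3C#N)c2C#N)cc1` reads > 20000 nM, which is a limit. Compound 2 `CCc1ccc(-c2nc3c(c(C)nn3-c3ccccc3)c(-c3ccccc3OC(F)(F)F)c2C#N)cc1` reads > 20000 nM, also a limit. Most of the data thus sit at the limit of > 20000 nM in this assay, at which 2 of the 3 values shown sit. Among the compounds with values here, the one measured step is a step that the two limits leave unreadable from compound 1 to compound 2, and it concerns a different group. Compound 4 `Cc1nn(-c2ccccc2)c2nc(-c3ccc(Cl)cc3)c(C#N)c(-c3ccccc3O)c12` has 4-chlorophenyl in place of 2-methylphenyl on an aromatic carbon. With no readable step to go on, the expectation leans on compound 3 at 21000 nM. The expected change is a 1.1-fold lower number from compound 3 to compound 4 (0.02 log units; within the scatter), no step beyond the usual scatter and in no set direction. For compound 4 the estimate is 20000 nM, with an expected range from 10000 nM to 40000 nM.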

Compound 4, half-maximal effective concentration: > 20000 nM
Compound 4 ended at the assay's limit (the forecaster's own chance of this, stated with the estimate: 50%); the middle value sits exactly at the limit.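

Compound 4 gives only a limit, so no size can be read for the change from compound 3 to compound 4. What stays open is whether 4-chlorophenyl in place of 2-methylphenyl shifts the read-out at all, as most values sit at one limit: the limit of > 20000 nM in this assay, at which 3 of the 4 values shown sit.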